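The source may hold more compounds than are shown below. What is called first, only, known or untested is meant among the compounds shown, and "the series" means these compounds.

The series is followed in a functional assay on HL-60 cells (Homo sapiens) for inhibition, read by MTT assay, with a stated time of 72 h; a lower number here means a stronger inhibitor, a higher number a weaker inhibitor. Compound 1 `Cc1ccc(N2CCN(C(=O)c3oc(C)nc3-c3ccccc3)CC2)cc1` gives there only a limit of the assay, > 1000 nM, which is the limit of > 1000 nM in this assay, at which 1 of the 3 values shown sits. For the measured compounds named here, compound 2 `COc1cc(OC)cc(N2CCN(C(=O)c3onc(C)c3-c3ccc(-c4ccco4)cc3)CC2)c1` gives 191 nM as a number, and compound 3 `CCc1nc(-c2ccc(F)cc2)c(C(=O)N2CCN(c3cccc(OC)c3)CC2)o1` gives 411 nM; neither differs from compound 1 in a single place, so no step between measured compounds is available. Compound 4 `CC(=O)Nc1cccc(N2CCN(C(=O)c3oc(C)nc3-c3ccccc3)CC2)c1` has not yet been measured; it differs from compound 1 by 3-acetamidophenyl in place of 4-methylphenyl on an amine nitrogen in a ring. With compound 1 standing at the limit, the step expected in this assay is a step that the limit leaves unreadable from compound 1 to compound 4, small or none beyond the scatter, and a limit is again a likely outcome. Compound 4 is estimated at 1500 nM, with a range from 400 nM to 6000 nM.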

Compound 4, half-maximal inhibitory concentration: 329 nM
Estimate against measurement, compound 4: 4.6-fold (0.66 log units) above, and the stated range ends above it.
By their numbers in this assay, from the lowest: compounds 2, 4 and 3 (each within the scatter of the next, the first and the last beyond it). At a limit, above all of these: compound 1.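

In this assay, the group on the amine nitrogen of the ring is now shown to matter: 3-acetamidophenyl in place of 4-methylphenyl gives an at least 3.0-fold lower number from compound 1 to compound 4 (0.48 log units; beyond the scatter). For the compounds shown here, this is the first single-place comparison, and the earlier compounds offered no such pair. Compound 1 stands at a limit: the limit of > 1000 nM in this assay, at which 1 of the 4 values shown sits.

The change replaces the whole group, so the compounds shown do not separate the acetamide from its place on the phenyl ring. On these data alone, whether a sulfonamide or an amine on that phenyl ring would give a similar step remains open.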